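The source may hold more compounds than are shown below. What is called first, only, known or untested is meant among the compounds shown, and "the series" means these compounds.

Compound 1 `O=C1COc2ccc(-c3cnc4ccccc4c3)cc2N1` is measured only as a limit: in a functional assay on MCF7 cells (Homo sapiens) for antiproliferative activity, read by MTT assay, with a stated time of 72 h (a higher number here means a weaker inhibitor, a lower number a stronger inhibitor), compound 1 gives > 40000 nM.
Compound 2 `COc1ncc(-c2ccc3c(c2)N(C2CCCCC2)C(=O)CO3)cc1NS(=O)(=O)c1ccc(F)cc1` gives 30100 nM.
Compound 3 `COc1ncc(-c2ccc3c(c2)N(C(C)C)C(=O)CO3)cc1NS(=O)(=O)c1ccc(F)cc1` gives 17000 nM.

Compound 1 therefore has no number of its own, only a limit (the limit of > 40000 nM in this assay, at which 1 of the 3 values shown sits), so its place among the measured compounds cannot be fixed. Compound 4 `O=C1COc2ccc(-c3cnc4ccccc4c3)cc2N1c1ccc(F)cc1` differs from it in one place (4-fluorophenyl in place of hydrogen on an amide-type nitrogen in a ring). For the measured compounds named here, the only measured step at that position is a 1.8-fold lower number from compound 2 to compound 3 (0.25 log units; within the scatter), a swap of one substituent for another on the same nitrogen that stayed within the scatter. Compounds 2 and 3 differ from compound 1 in more than one place, so their values only show that both are weak inhibitors. Going by the values given here, no measured step covers the change from hydrogen to 4-fluorophenyl itself. The expectation for compound 4 is thus a step of a number no higher from compound 1 to compound 4 (the limit leaves the size open), with no change beyond the scatter. The estimated value for compound 4 is 40000 nM, within 12000 nM to 120000 nM, and a limit rather than a number is likely to be reported again.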

Compound 4, half-maximal inhibitory concentration: > 40000 nM
Compound 4: a limit, no number; the forecaster's own chance of this, stated with the estimate: 55%; the middle value sits exactly at the limit.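

Compound 1 and compound 4 are both reported only as limits in this assay, so no step between them can be read: the limit of > 40000 nM in this assay, at which 2 of the 4 values shown sit.

The compounds shown leave open whether 4-fluorophenyl in place of hydrogen on the amide-type nitrogen changes antiproliferative activity at all.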